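The source may hold more compounds than are shown below. What is called first, only, known or untested is meant among the compounds shown, and "the series" means these compounds.

In a functional assay on PC-3 cells (Homo sapiens) for antiproliferative activity, read by MTT assay, with a stated time of 24 h (on this read-out lower numbers stand for stronger inhibition and higher numbers for weaker inhibition), the amides built on one shared core have so far given closely grouped numbers. Compound 1 `CCn1c(C(=O)N[C@@H](CO)CCO)ccc1C(CC)(CC)c1ccc(OCS(=O)(=O)c2ccccc2)c(C)c1` gives 14100 nM, compound 2 `CCn1c(C(=O)N[C@@H](CO)CCCO)ccc1C(CC)(CC)c1ccc(OCS(=O)(=O)c2ccccc2)c(C)c1` gives 13400 nM, and compound 3 `CCn1c(C(=O)N[C@@H](C)C(=O)O)ccc1C(CC)(CC)c1ccc(OCS(=O)(=O)c2ccccc2)c(C)c1` gives 16800 nM. Compound 3 therefore stands within the scatter of both other compounds, and these data cannot rank it against them.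

Compound 4 `CCn1c(C(=O)N[C@@H](CC(=O)O)C(=O)O)ccc1C(CC)(CC)c1ccc(OCS(=O)(=O)c2ccccc2)c(C)c1` differs from compound 3 in one place: carboxy in place of hydrogen on a saturated chain carbon, two bonds along the chain from an amide-type nitrogen and a carbonyl carbon. The 1-carboxyethyl group on the amide-type nitrogen thus becomes 1,2-dicarboxyethyl.

The measured steps offer only indirect guidance. Replacing hydroxy with hydroxymethyl gives a 1.1-fold lower number from compound 1 to compound 2 (0.02 log units; within the scatter). Moving to the 1-carboxyethyl group gives a 1.2-fold higher number from compound 1 to compound 3 (0.08 log units; within the scatter) and also a 1.3-fold higher number from compound 2 to compound 3 (0.10 log units; within the scatter). All of these steps lie within the scatter, but none of them adds carboxy to a group that already carries one, so the new change has not itself been tested.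

With only these small steps as a precedent, no shift beyond the scatter is expected in this assay, although the uncertainty is wide. The expected change is a 1.0-fold higher number from compound 3 to compound 4 (0.01 log units; within the scatter). The estimated value for compound 4 is 17000 nM, with an expected range from 9000 nM to 32000 nM.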

Compound 4, half-maximal inhibitory concentration: > 50000 nM
Compound 4 gave a limit, no number; the forecaster's own chance of this, stated with the estimate: 10%; middle value at least 2.9-fold (0.46 log units) away from the limit.
By their numbers in this assay, from the lowest: compounds 2, 1 and 3 (each within the scatter of the next). At a limit, above all of these: compound 4.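

In this assay compound 4 gives a limit of the assay, not a number: the limit of > 50000 nM in this assay, at which 1 of the 4 values shown sits.

Carboxy in place of hydrogen on this saturated chain carbon, two bonds along the chain from an amide-type nitrogen and a carbonyl carbon, is the first change here to move the read-out beyond the scatter, with an at least 2.9-fold higher number from compound 3 to compound 4 (0.47 log units; beyond the scatter), so this position is not indifferent to what it carries. Compound 4 also separates from the two amides bearing hydroxy groups, with an at least 3.7-fold higher number from compound 2 to compound 4 (0.57 log units; beyond the scatter) and an at least 3.5-fold higher number from compound 1 to compound 4 (0.54 log units; beyond the scatter), whereas compound 3, with its single carboxy, stays within the scatter of both, so among these four compounds only the 1,2-dicarboxyethyl group sets a compound apart.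

On these data alone, as compound 4 gives only a limit, the true size of these steps stays unknown. The compounds shown also leave open whether the loss belongs to carboxy itself or would follow from other groups on this carbon, such as an amine, a methyl ester, a primary amide or a longer chain ending in a carboxylic acid.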